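Swapping an Isoquinoline Amide for a Triazolylphenyl Amide

A few compounds are considered here, and "the series" means these few. Any claim that something is new, unique, unknown or untested is made for them only; others in the source may bear on it.

Of the compounds shown here, two sharing one core have been measured in an assay on brain for displacement of a labelled ligand from D(3) dopamine receptor (Rattus norvegicus); a higher number here means a weaker inhibitor, a lower number a stronger inhibitor: compound 2 `CCCN(CC[C@H]1CC[C@H](NC(=O)c2cccc3cnccc23)CC1)[C@H]1CCc2nc(N)sc2C1` gives 5.9 nM, and compound 1 `CCCN(CC[C@H]1CC[C@H](NC(=O)/C=C/c2cccc(F)c2)CC1)[C@H]1CCc2nc(N)sc2C1` gives 9.9 nM, numbers that do not differ beyond the scatter. Compound 3 `CCCN(CC[C@H]1CC[C@H](NC(=O)c2ccc(-n3cncn3)cc2)CC1)[C@H]1CCc2nc(N)sc2C1` differs from compound 2 by 4-(1H-1,2,4-triazol-1-yl)phenyl in place of isoquinolin-5-yl on a carbonyl carbon. Within the data shown here, the only measured step bearing on this, a 1.7-fold lower number from compound 1 to compound 2 (0.22 log units; within the scatter), also exchanged the group on the carbonyl carbon and stayed within the scatter, so a similarly small step is expected here, with no firm direction. Compound 3 is therefore estimated at 8 nM, ranging from 3 nM to 25 nM. This expected step, a 1.4-fold higher number from compound 2 to compound 3 (0.13 log units; within the scatter), is not expected to exceed the scatter.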

Compound 3, inhibition constant: 2.4 nM
The estimate for compound 3 lay 3.3-fold (0.52 log units) above the measured number; the measured number lies below the stated range.
By their numbers in this assay, from the lowest: compound 3; then compounds 2 and 1 (each within the scatter of the next).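

In this assay, the group on the carbonyl carbon can move the number beyond the scatter, which the earlier pair did not show. With 4-(1H-1,2,4-triazol-1-yl)phenyl at this place, a 2.5-fold lower number from compound 2 to compound 3 (0.39 log units; beyond the scatter) and a 4.1-fold lower number from compound 1 to compound 3 (0.62 log units; beyond the scatter) both pass that limit, though only modestly. No measurement at hand explains this gain.

Going by these compounds, it remains open whether the triazole ring or the phenyl ring carrying it matters more. Also open, on these data alone, is whether an amine or a carboxylic acid in place of the triazole would keep the number this low.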